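The source may hold more compounds than are shown below. What is called first, only, known or untested is meant among the compounds shown, and "the series" means these compounds.

Measured compounds:

Compound 1 `Nc1ccccc1NC(=O)c1ccc(CSC(=S)N2CCN(Cc3ccccn3)CC2)cc1`; in a functional assay on HeLa cells (Homo sapiens) for antiproliferative activity, read by CCK-8 assay, with a stated time of 72 h, tested at 8 uM (on this read-out higher numbers stand for a stronger effect at the one concentration tested and lower numbers for a weaker effect), compound 1 gives 61.4%.
Compound 2 `Nc1ccccc1NC(=O)c1ccc(CSC(=S)N2CCN(c3ccc(Cl)cc3)CC2)cc1`; in this assay compound 2 gives 44.8%.
Compound 3 `Nc1ccccc1NC(=O)c1ccc(CSC(=S)N2CCN(Cc3cccnc3)CC2)cc1`; in this assay compound 3 gives 78%.

Among these three numbers compound 1 stands second highest: compound 2 lies below it, as a number 16.6 percentage points lower from compound 1 to compound 2 (beyond the scatter) shows, and compound 3 lies above it, as a number 16.6 percentage points higher from compound 1 to compound 3 (beyond the scatter) shows. Compound 4 `Nc1ccccc1NC(=O)c1ccc(CSC(=S)N2CCN(c3ccccc3F)CC2)cc1` has not yet been measured. It differs from compound 1 in one place: 2-fluorophenyl in place of (pyridin-2-yl)methyl on an amine nitrogen in a ring. Among the measured compounds shown here, the step that bears on this change is the one from compound 1 to compound 2, where a 4-chlorophenyl group likewise took the place of the (pyridin-2-yl)methyl group on the ring amine nitrogen and gave a number 16.6 percentage points lower from compound 1 to compound 2 (beyond the scatter). The step from compound 2 to compound 3, a number 33.2 percentage points higher from compound 2 to compound 3 (beyond the scatter), points the same way, since removing such a ring from the amine nitrogen in favour of a (pyridin-3-yl)methyl group raised the number. A modest downward step, a number 15.4 percentage points lower from compound 1 to compound 4 (beyond the scatter), is therefore expected for compound 4 in this assay. Compound 4 is estimated at 46%, within a range of 30% to 62%.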

Compound 4, a percentage reported as inhibition, at one concentration (the size of the read-out at that concentration, not a potency): 59.2%
Compound 4: the middle estimate sits 13.2 percentage points below what was measured; the range from low to high includes it.
By their numbers in this assay, from the lowest: compound 2; then compounds 4 and 1 (each within the scatter of the next); then compound 3.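

In this assay, the change to 2-fluorophenyl gives a number 2.2 percentage points lower from compound 1 to compound 4 (within the scatter), so a halogen-bearing phenyl group on the amine nitrogen does not always bring the drop that compound 2 alone suggested. The outcome depends on which such phenyl group is present, as a number 14.4 percentage points higher from compound 2 to compound 4 (beyond the scatter) shows, while a number 18.8 percentage points lower from compound 3 to compound 4 (beyond the scatter) shows that compound 4 still does not reach the level of the (pyridin-3-yl)methyl compound. No measurement at hand explains these differences.

The 2-fluorophenyl and 4-chlorophenyl groups differ in both the halogen and its place on the ring, and the compounds shown do not separate these two changes. Also open, going by these compounds, is how a plain phenyl or benzyl group, with no halogen and no ring nitrogen, would read in this assay.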